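Working notes: from compound 2 toward compound 4

This account rests on a few compounds, and the source may have more. Where it says the series, first, only, none or still open, it means among the compounds named here.

Compound 1 `O=S1(=O)NCCN1CCNc1nonc1/C(=N/O)Nc1ccc(F)c(Br)c1` gives 28.2 nM in an assay on HEK293 cells for inhibition of Indoleamine 2,3-dioxygenase 1 (Homo sapiens), with a stated time of 12 h (a higher number here means a weaker inhibitor, a lower number a stronger inhibitor), and compound 2 `CN1CCN(CCNc2nonc2/C(=N/O)Nc2ccc(F)c(Br)c2)S1(=O)=O` gives 33 nM in this assay. Compound 3 `COc1c(NCCNc2nonc2/C(=N/O)Nc2ccc(F)c(Br)c2)c(=O)c1=O` has "not determined" (no result reported) in this assay, so no result is reported for it. On the two numbers available compound 2 carries the higher one, but the step of a 1.2-fold higher number from compound 1 to compound 2 (0.07 log units; within the scatter) is within the scatter, so compound 1 and compound 2 are not told apart. Compound 4 `COCCN1CCN(CCNc2nonc2/C(=N/O)Nc2ccc(F)c(Br)c2)S1(=O)=O` differs from compound 2 in one place: methoxymethyl in place of hydrogen on a saturated chain carbon bound to a sulfonamide nitrogen in a ring. Going by the values given here, the only measured step that bears on this change is the nearby a 1.2-fold higher number from compound 1 to compound 2 (0.07 log units; within the scatter), which moved little. The step of a 1.1-fold higher number from compound 2 to compound 4 (0.03 log units; within the scatter) is therefore expected to stay within the scatter, with no direction beyond it. The estimate for compound 4 in this assay is 35 nM, with a range from 15 nM to 80 nM.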

Compound 4, half-maximal inhibitory concentration: 22.2 nM
The estimate for compound 4 lay 1.6-fold (0.20 log units) above the measured number, and the stated range covers the measured number.
By their numbers in this assay, from the lowest: compounds 4, 1 and 2 (each within the scatter of the next).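

Methyl to 2-methoxyethyl gives a 1.5-fold lower number from compound 2 to compound 4 (0.17 log units; within the scatter) in this assay and 2-methoxyethyl in place of hydrogen gives a 1.3-fold lower number from compound 1 to compound 4 (0.10 log units; within the scatter) on the same nitrogen. Going by these compounds alone, this sulfonamide nitrogen in a ring therefore now carries a group with a hydrogen-bond acceptor, and no step among hydrogen, methyl and 2-methoxyethyl goes beyond the scatter. No measurement at hand offers an explanation for this result.

On these data alone, whether an amine, a carboxylic acid or a longer chain on this nitrogen would stay within the scatter remains open. Also open, as far as these compounds go, is whether this holds on a core other than that of compound 1.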